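This account rests on a few compounds, and the source may have more. Where it says the series, first, only, none or still open, it means among the compounds named here.

Measured compounds:
compound 1, `O=C(CN1CCN(c2cc3c(cc2F)c(=O)c(C(=O)O)cn3C2CC2)CC1)Nc1ccc(C(=O)/C=C/c2ccccc2Cl)cc1`, which in a physicochemical assay for solubility, at pH 7.8 (on this read-out higher numbers stand for higher solubility and lower numbers for lower solubility), gives 2.12 ug/mL
compound 2, `O=C(CN1CCN(c2cc3c(cc2F)c(=O)c(C(=O)O)cn3C2CC2)CC1)Nc1ccc(C(=O)/C=C/c2cccc(Cl)c2)cc1`, which in this assay gives 29.7 ug/mL

Compound 2 holds the higher of the two numbers; its nearest neighbour, compound 1, lies below it by the step of a 14-fold higher number from compound 1 to compound 2 (1.15 log units; beyond the scatter), a difference that sits beyond the scatter.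

Compound 3, `COc1cc(/C=C/C(=O)c2ccc(NC(=O)CN3CCN(c4cc5c(cc4F)c(=O)c(C(=O)O)cn5C4CC4)CC3)cc2)cc(OC)c1OC`, has not yet been measured in this assay. It is built from compound 2 by the change (3,4,5-trimethoxyphenyl in place of 3-chlorophenyl on a double-bonded chain carbon bound to a double-bonded chain carbon), so that an entering group counted with 3 hydrogen-bond acceptors replaces one counted with none.

Going by the values given here, only one measured step exists, a 14-fold higher number from compound 1 to compound 2 (1.15 log units; beyond the scatter), and it concerns a chlorine moved from one position of the phenyl to another, not an exchange of the phenyl's substituents for three methoxy groups. That step therefore says little about the present change beyond showing that this part of the molecule can move the number a good deal. Compound 3 is estimated at 40 ug/mL, with a range from 10 ug/mL to 150 ug/mL, which corresponds to an expected step of a 1.3-fold higher number from compound 2 to compound 3 (0.13 log units; within the scatter), small enough that no change beyond the scatter is firmly expected.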

Compound 3, solubility: 2.01 ug/mL
Estimate against measurement, compound 3: 20-fold (1.30 log units) above, and the stated range ends above it.
By their numbers in this assay, from the lowest: compounds 3 and 1 (each within the scatter of the next); then compound 2.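

In this assay, 3,4,5-trimethoxyphenyl in place of 3-chlorophenyl on a double-bonded chain carbon bound to a double-bonded chain carbon gives a 15-fold lower number from compound 2 to compound 3 (1.17 log units; beyond the scatter), so an exchange of the whole substituent pattern at this place, and not only a shift of the chlorine, can produce a large step. The same group in place of 2-chlorophenyl gives a 1.1-fold lower number from compound 1 to compound 3 (0.02 log units; within the scatter), which lies within the scatter, so compound 1 and compound 3 cannot be told apart on this read-out, even though the groups they carry differ in their atoms and in their counted hydrogen-bond acceptors. Compound 2 thus stands alone among the three, beyond the scatter from both of the others, and the number does not follow the acceptor count, since compound 1 and compound 2 share the same count yet lie on either side of that large step.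

The evidence at hand offers no explanation for why 3-chlorophenyl stands apart from the other two groups. From the compounds shown here alone, it also remains open whether an amine or a carboxylic acid on this phenyl, or a single methoxy group in place of the three, would give a number closer to that of compound 2 or to those of compound 1 and compound 3.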